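Swapping the saturated oxygen ring on the core of compound 1

The source may report more compounds than this note shows. Statements on the series, on what has been measured and on what is new or still open speak of the compounds shown alone.

Measured compounds in a physicochemical assay for solubility, measured as kinetic solubility; a lower number here means a less soluble compound, a higher number a more soluble compound:
compound 1 `Cc1cc(C)c(CN2CCc3c(Cl)cc([C@@H](CO)[C@@H]4CCOC4)c(Cl)c3C2=O)c(=O)[nH]1` with 537000 nM
compound 2 `COC(c1cc(Cl)c2c(c1Cl)C(=O)N(Cc1c(C)cc(C)[nH]c1=O)CC2)C1CCN(C2COC2)CC1` with 523000 nM; 519000 nM (2 entries)
compound 3 `COc1cc(C)[nH]c(=O)c1CN1CCc2c(Cl)cc(-c3c(C)noc3C)c(Cl)c2C1=O` with 384000 nM

Of the compounds shown here, three share the core and have been measured in this assay. Compound 1 gives 537000 nM. Compound 3 gives 384000 nM; the gap between compound 1 and compound 3 lies within the usual scatter, so neither can be placed above the other. Compound 2 has been run more than once, and its repeated entries the several entries of compound 2 in this assay, 523000 nM; 519000 nM (2 entries) sit close together. No two of these three compounds differ in only one place, so no single measured step can be read from them.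

The unmeasured compound 4 `Cc1cc(C)c(CN2CCc3c(Cl)cc([C@H](CO)[C@H]4CCCO4)c(Cl)c3C2=O)c(=O)[nH]1` is built from the same atoms as compound 1, joined differently. The change is a group of 8 heavy atoms (6 carbon, 2 oxygen; one five-membered non-aromatic ring with 1 hetero atom) in place of a group of 8 heavy atoms (6 carbon, 2 oxygen; one five-membered non-aromatic ring with 1 hetero atom), on an aromatic carbon. Among the measured compounds shown here, the group that leaves and the group that enters are counted alike, so the only change is how the five-membered non-aromatic ring with one hetero atom is attached and where its stereocentres fall.

Given the small size of this rearrangement and the narrow spread among the measured compounds, the step from compound 1 to compound 4 in this assay is expected to be none beyond the scatter, and the estimate is a 1.1-fold lower number from compound 1 to compound 4 (0.03 log units; within the scatter). Compound 4 is therefore expected to give about 500000 nM, within a range from 250000 nM to 900000 nM.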

Compound 4, solubility: 430000 nM
The estimate for compound 4 lay 1.2-fold (0.07 log units) above the measured number; the measured number falls inside the stated range.
By their numbers in this assay, from the lowest: compounds 3, 4 and 1 (each within the scatter of the next).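

Among the compounds shown here, the step gives the first reading of a single change on the shared core: in this assay, there is a 1.2-fold lower number from compound 1 to compound 4 (0.10 log units; within the scatter). On this aromatic carbon, ortho to a chloro group and meta to a chloro group, changing how the five-membered non-aromatic ring with 1 hetero atom is attached and where its stereocentres fall therefore does not separate the two compounds, while the counted make-up of the group stays the same. The only repeat readings shown belong to a different compound, and they sit close together: the several entries of compound 2 in this assay, 523000 nM; 519000 nM (2 entries).

The attachment of the ring and the placing of its stereocentres differ together in this one step, so the compounds shown cannot tell what each contributes on its own. As far as these compounds go, it also remains open whether the read-out would stay within the scatter if a group with a different make-up stood at this place, for example a carboxylic acid or a longer chain on the five-membered ring.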